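Extending the terminal amide of a ketoamide calpain inhibitor

The source may hold more compounds than are shown below. What is called first, only, known or untested is meant among the compounds shown, and "the series" means these compounds.

Three peptide ketoamides and esters have been examined in an assay on isolated protein (Oryctolagus cuniculus) for inhibition of Calpain-2 catalytic subunit (Homo sapiens), at pH 8.0 (a lower number here means a stronger inhibitor, a higher number a weaker inhibitor), so far. Compound 1 `CCOC(=O)C(=O)C(CC)NC(=O)C(CC(C)C)NC(=O)OCC(C)C` gives 17000 nM, compound 2 `CCC(NC(=O)C(CC(C)C)NC(=O)OCc1ccccc1)C(=O)C(=O)NCCCc1ccccc1` gives 43 nM, and compound 3 `CCCC(NC(=O)C(CC(C)C)NC(=O)OCc1ccccc1)C(=O)C(N)=O` gives 78 nM. Compound 3 thus stands second highest of the three numbers; its value and that of compound 2 lie within the usual scatter of each other, while compound 1 lies far beyond it. Compound 4 `CCCC(NC(=O)C(CC(C)C)NC(=O)OCc1ccccc1)C(=O)C(=O)NCC` differs from compound 3 in one place: ethyl in place of hydrogen on an amide-type nitrogen. Among the compounds with values here, no measured pair shows this change, so the step is expected to be small, in either direction or none beyond the scatter. For compound 4 the expected result is 55 nM, between 20 nM and 160 nM, a step of a 1.4-fold lower number from compound 3 to compound 4 (0.15 log units; within the scatter).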

Compound 4, inhibition constant: 88 nM
Compound 4: the middle estimate sits 1.6-fold (0.20 log units) below what was measured, within the range that was stated.
By their numbers in this assay, from the lowest: compounds 2, 3 and 4 (each within the scatter of the next, the first and the last beyond it); then compound 1.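

In this assay, within the data shown here, the first pair to isolate this position shows a 1.1-fold higher number from compound 3 to compound 4 (0.05 log units; within the scatter) when ethyl takes the place of hydrogen on the amide-type nitrogen. For this one pair, then, the amide hydrogen can give way to ethyl with no step beyond the scatter. No available evidence bears on this result. Still open, from the compounds shown here alone, is whether a longer chain, an amine or a carboxylic acid on this nitrogen would also stay within the scatter of compound 3. Also open, going by these compounds, is what a second ethyl in place of the remaining amide hydrogen would do.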